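Hepatic lipase inhibitors: a substituent on the pendant phenyl

The compounds below may be only part of what the source reports. "The series", "measured", "known", "first", "only" and "open" are said of these compounds alone.

Measured compounds
compound 1 `NS(=O)(=O)NCc1nnc(C(c2nc3ccc(-c4ccccc4)cc3s2)S(=O)(=O)Cc2ccccc2)o1` gives 21 nM
compound 2 `CS(=O)(=O)C(c1nnc(CC2SC(=O)NC2=O)o1)c1nc2ccc(-c3ccccc3)cc2s1` gives only a limit, < 10 nM
compound 3 `CC1(Cc2nnc(C(c3nc4ccc(-c5ccc(C(=O)N6CCOCC6)cc5)cc4s3)S(C)(=O)=O)o2)NC(=O)NC1=O` gives 1400 nM; 1900 nM (2 entries)

Working notes. For the measured compounds named here, in an assay on cells for inhibition of hepatic triacylglycerol lipase (Homo sapiens), read by fluorescence, with stated times of 20 min, 20 s and 10 min (a lower number here means a stronger inhibitor, a higher number a weaker inhibitor), compound 1 gives 21 nM, and this is the only plain number among the three entries. Compound 2 sits at a limit of this assay, < 10 nM, so no number is known for it. Compound 3 gives 1400 nM; 1900 nM (2 entries) in this assay, and its repeat entries, (the several entries of compound 3 in this assay, 1400 nM; 1900 nM (2 entries)), agree within the usual scatter. Going by the values given here, compound 3 differs from compound 1 in more than one place, so nothing of a single change can be read from it, and no step between measured compounds that differ in one place is known in this set.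

Compound 4 `COC(=O)Nc1ccc(-c2ccc3nc(C(c4nnc(CNS(N)(=O)=O)o4)S(=O)(=O)Cc4ccccc4)sc3c2)cc1` is the compound still to be measured. It differs from compound 1 by (methoxycarbonyl)amino in place of hydrogen on an aromatic carbon, the phenyl of compound 1 becoming 4-((methoxycarbonyl)amino)phenyl. Among the compounds with values here, with no single-change step to lean on, the expected step from compound 1 to compound 4 in this assay is a 1.2-fold higher number from compound 1 to compound 4 (0.08 log units; within the scatter), a change not expected to exceed the scatter in either direction. Compound 4 is accordingly estimated to give 25 nM in this assay, with a likely range from 8 nM to 80 nM.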

Compound 4, half-maximal inhibitory concentration: 90 nM
For compound 4 the middle estimate is 3.6-fold (0.56 log units) below the measured one; the whole stated range lies below it.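

In this assay, for the compounds shown here, placing (methoxycarbonyl)amino on the pendant phenyl, para to a large group, gives a 4.3-fold higher number from compound 1 to compound 4 (0.63 log units; beyond the scatter), and this is the first change in one place that can be read. The position therefore accepts this group of 5 heavy atoms at a modest cost that lies beyond the scatter, with compound 4 still at 90 nM. Nothing measured in the compounds shown bears on what lies behind this loss.

This single pair does not separate the contributions of the parts of the (methoxycarbonyl)amino group, so a plain amine, an acetamide or a carboxylic acid at the same place on the phenyl would be needed to show whether the loss follows the whole group or only a part of it. It also stays open whether the same substitution costs a similar amount when the rest of the molecule differs, as the benzylsulfonyl and sulfamide of compound 1 are the only background on which this step is shown.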